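Fluoro in place of hydroxy on compound 3

The source may hold more compounds than are shown below. What is called first, only, known or untested is meant among the compounds shown, and "the series" means these compounds.

Values in a functional assay on P388 cells (Mus musculus) for cytotoxicity; on this read-out lower numbers stand for an effect already at smaller amounts and higher numbers for an effect only at larger amounts of compound
- compound 1 `c1ccc(COc2cc(-c3ccccc3)nc3ccccc23)cc1` gives > 10 ug/mL, a limit of the assay
- compound 2 `Oc1ccc2nc(-c3ccccc3)cc(O)c2c1` gives 2.86 ug/mL
- compound 3 `Oc1ccc2c(O)cc(-c3ccccc3)nc2c1` gives 0.81 ug/mL

Compound 3 holds the lower of the two actual numbers, and compound 2 lies higher by a gap beyond the usual scatter. Compound 1 is reported only as a limit, so it gives no number to rank.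

Compound 4 `Oc1cc(-c2ccccc2)nc2cc(F)ccc12` is the next to be read. It carries fluoro in place of hydroxy on an aromatic carbon of a six-membered aromatic ring of carbon only (fluoro in place of hydroxy on an aromatic carbon). Going by the values given here, no measured step covers this change, so the expectation is loose. Among the compounds with values here, it rests on compound 3 at 0.81 ug/mL being the lowest number so far, which leaves more room for a single change to move upward. A modest estimated step of a 2.2-fold higher number from compound 3 to compound 4 (0.35 log units; beyond the scatter) towards a higher number is expected in this assay. The estimate for compound 4 is 1.8 ug/mL, with an expected range of 0.5 ug/mL to 8 ug/mL.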

Compound 4, half-maximal effective concentration: 0.29 ug/mL
Compound 4: middle estimate off by 6.2-fold (0.79 log units), on the high side, outside the stated range (below it).
By their numbers in this assay, from the lowest: compound 4; then compound 3; then compound 2. At a limit, above all of these: compound 1.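

In this assay, the hydroxy on the aromatic carbon of the six-membered ring of carbon only is not needed to keep a low number: fluoro, with 0 hydrogen-bond donors and 0 hydrogen-bond acceptors, takes its place and gives a 2.8-fold lower number from compound 3 to compound 4 (0.45 log units; beyond the scatter). Going by these compounds alone, this step is the first one-place change, and it shows that this position tolerates the swap and that the change lowers the number beyond the scatter. Nothing measured here offers a reason for the step.

Open, from the compounds shown here alone, is whether the step comes from losing hydroxy or from gaining fluoro, which a plain hydrogen at this position would separate. Also open, going by these compounds, is how chloro, methoxy or an amine at the same carbon would read in this assay, and what part the remaining hydroxy, shared by compound 3 and compound 4, plays.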